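Trifluoromethyl for nitro on a compound at the assay limit

The source may report more compounds than this note shows. Statements on the series, on what has been measured and on what is new or still open speak of the compounds shown alone.

The series shares one core, seen in compound 1 `O=[N+]([O-])c1ccccc1CNc1cc(Br)cc2cn[nH]c12`, compound 2 `O=[N+]([O-])c1cccc(CNc2cc(C(F)(F)F)cc3[nH]ncc23)c1` and compound 3 `O=[N+]([O-])c1cccc(CNc2cc(Br)cc3[nH]ncc23)c1`. In an assay for inhibition of Indoleamine 2,3-dioxygenase 1 (Homo sapiens), with stated times of 10 min and 60 min (a lower number here means a stronger inhibitor, a higher number a weaker inhibitor), compound 1 gives only a limit, > 100000 nM. In this assay compound 2 likewise gives only a limit, > 100000 nM. Compound 3 gives a number in this assay, 7950 nM, and the step of an at least 12-fold lower number from compound 2 to compound 3 (1.09 log units; beyond the scatter) shows a bromo in place of trifluoromethyl on the core. Compound 2 thus stands at the limit, one of the two values that sit there (the limit of > 100000 nM in this assay, at which 2 of the 3 values shown sit). Going by the values given here, compound 4 `FC(F)(F)c1cccc(CNc2cc(C(F)(F)F)cc3[nH]ncc23)c1` differs from compound 2 by trifluoromethyl in place of nitro on an aromatic carbon, a change at a place no measured step touches, so the measured step from compound 2 to compound 3 does not bear on it. With no guidance, compound 4 is expected to remain at the limit, with an estimated step of a number no higher from compound 2 to compound 4 (the limit leaves the size open) not beyond the scatter. The estimate for compound 4 is 100000 nM, between 30000 nM and 300000 nM.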

Compound 4, half-maximal inhibitory concentration: > 100000 nM
Compound 4: no number, only a limit; the forecaster's own chance of this, stated with the estimate: 75%; the middle value lies on the limit itself.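

Compound 4 gives only a limit in this assay, as compound 2 does, so no step between the two can be read: the limit of > 100000 nM in this assay, at which 3 of the 4 values shown sit.

The compounds shown leave open what trifluoromethyl in place of nitro does to inhibition, including on the bromo-bearing compound 3, which gives a number.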